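The source may report more compounds than this note shows. Statements on the series, on what has been measured and on what is new or still open speak of the compounds shown alone.

Series notes. Compound 1 `COc1ccc(OC)c(/C=C/C(=O)N/N=C/c2ccccc2)c1` carries no number in a functional assay on DU-145 cells (Homo sapiens) for antiproliferative activity, read by sulforhodamine B assay, with a stated time of 48 h; on this read-out lower numbers stand for higher toxicity in this test and higher numbers for lower toxicity in this test: its entry reads "not determined" (no result reported). Going by the values given here, compound 2 `COc1ccc(OC)c(/C=C/c2nnc(Nc3ccc(Cl)cc3)o2)c1` is the only measured member, and in this assay compound 2 gives > 100000 nM, which is a limit of the assay rather than a number. Among the compounds with values here, the single value that exists therefore sits at the limit of > 100000 nM in this assay, at which 1 of the 2 values shown sits. Compound 3 `COc1ccc(OC)c(/C=C/C(=O)N/N=C/c2ccc(Cl)cc2)c1` differs from compound 1 by chloro in place of hydrogen on an aromatic carbon. Within the data shown here, with no measured step to draw on, no change in this assay beyond the usual scatter is expected from this alteration, in either direction. Compound 3 is expected to give about 70000 nM in this assay, plausibly between 15000 nM and 150000 nM, with a real chance that only a limit is reported.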

Compound 3, concentration lethal to 50% of the cells: > 100000 nM
Compound 3: a limit, no number; the forecaster's own chance of this, stated with the estimate: 60%; middle value at least 1.4-fold (0.15 log units) from the limit.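

Going by these compounds alone, no step between compound 1 and compound 3 can be read: compound 3 gives > 100000 nM in this assay, a limit and not a number. The compounds shown leave open whether phenyl to 4-chlorophenyl changes this read-out at all.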